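Acetyl to methyl on the aryl oxygen of compound 1

A few compounds are considered here, and "the series" means these few. Any claim that something is new, unique, unknown or untested is made for them only; others in the source may bear on it.

Measured compounds:
compound 1, `C=C1[C@H](C)CCC[C@]1(C)CC[C@@]1(C)C=Cc2c(OC(C)=O)c(OC(C)=O)cc(OC)c2O1`: 3.06 ug/mL
compound 2, `C=C1[C@H](C)CCC[C@]1(C)CC/C(C)=C/CC1=C(OC)C(=O)C=C(OC)C1=O`: > 10 ug/mL

Of the compounds shown here, two have been tested in a functional assay on KB16 cells (Homo sapiens) for cytotoxicity, read by MTT assay; a lower number here means a stronger inhibitor, a higher number a weaker inhibitor. Compound 1, `C=C1[C@H](C)CCC[C@]1(C)CC[C@@]1(C)C=Cc2c(OC(C)=O)c(OC(C)=O)cc(OC)c2O1`, is the only one with a numerical result, giving 3.06 ug/mL. Compound 2, `C=C1[C@H](C)CCC[C@]1(C)CC/C(C)=C/CC1=C(OC)C(=O)C=C(OC)C1=O`, reaches only (the limit of > 10 ug/mL in this assay, at which 1 of the 2 values shown sits), and its reading of > 10 ug/mL is a limit of the assay rather than a number. Compound 1 therefore stands as the single fixed point against which anything further must be judged.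

Compound 3, `C=C1[C@H](C)CCC[C@]1(C)CC[C@@]1(C)C=Cc2c(OC(C)=O)c(OC)cc(OC)c2O1`, has not been measured in this assay. It differs from compound 1 by methyl in place of acetyl on an oxygen on an aromatic ring. Among the compounds with values here, no pair of measured compounds differing in one place is available, so the size of this step cannot be read from the data. The expectation is that the step from compound 1 to compound 3 stays within the usual scatter, with no clear direction, so that a 1.1-fold higher number from compound 1 to compound 3 (0.06 log units; within the scatter) is estimated as small. Compound 3 is thus expected to give about 3.5 ug/mL, within a range from 1.5 ug/mL to 8 ug/mL.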

Compound 3, half-maximal inhibitory concentration: 1.32 ug/mL
Compound 3: the middle estimate sits 2.7-fold (0.42 log units) above what was measured; the measured number lies below the stated range.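

In this assay, this oxygen on an aromatic ring does not need its acetyl group for activity: methyl in its place gives a 2.3-fold lower number from compound 1 to compound 3 (0.37 log units; beyond the scatter), so the change is tolerated and the number moves modestly in the stronger direction. Within the data shown here, this is the first step that can be read between two compounds differing in one place, as compound 2 differs from the others in more than one place and its reading is only a limit of the assay. No measurement shown accounts for the size or direction of this step.

The compounds shown leave open whether the gain comes from methyl itself or from the loss of acetyl, and how a free hydroxyl, an ethyl ether or a benzyl ether on the same oxygen would read in this assay. Also open, as far as these compounds go, is whether the acetoxy group that compound 3 keeps would respond in the same way to methyl in place of acetyl.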